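The source may report more compounds than this note shows. Statements on the series, on what has been measured and on what is new or still open speak of the compounds shown alone.

Two measured compounds share the same core, an amide built from a branched acid, and differ only in the group on the saturated chain carbon bound to the amide-type nitrogen. In an assay on brain for inhibition of Fatty-acid amide hydrolase 1 (Rattus norvegicus), read by scintillation counting, with a stated time of 10 min (on this read-out lower numbers stand for stronger inhibition and higher numbers for weaker inhibition), compound 1, with structure `CC(C)Cc1ccc(C(C)C(=O)NCc2cccc(C(F)(F)F)c2)cc1`, gives 28000 nM. Compound 2, with structure `COc1ccccc1CNC(=O)C(C)c1ccc(CC(C)C)cc1`, gives 18000 nM in this assay. These two numbers lie within the usual scatter of each other, so compound 2 cannot be set apart from compound 1 on the evidence shown; both inhibit only weakly.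

Compound 3, with structure `CC(C)Cc1ccc(C(C)C(=O)NCc2ccc(Cl)cc2Cl)cc1`, has not been measured in this assay. Its structure differs from compound 2 in one place: 2,4-dichlorophenyl in place of 2-methoxyphenyl on a saturated chain carbon bound to an amide-type nitrogen. Among the measured compounds shown here, no pair of measured compounds shows what this kind of exchange does, so there is no measured step to lean on; the only guide is that the one change already seen at this position, between compound 1 and compound 2, produced nothing beyond the scatter.

On that basis the expected step, a 1.1-fold lower number from compound 2 to compound 3 (0.05 log units; within the scatter), is none beyond the scatter. Compound 3 is therefore expected to give about 16000 nM in this assay, with a likely range from 5000 nM to 45000 nM.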

Compound 3, half-maximal inhibitory concentration: 21000 nM
For compound 3 the middle estimate is 1.3-fold (0.12 log units) below the measured one, within the range that was stated.
By their numbers in this assay, from the lowest: compounds 2, 3 and 1 (each within the scatter of the next).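

In this assay, 2,4-dichlorophenyl in place of 2-methoxyphenyl on a saturated chain carbon bound to an amide-type nitrogen gives a 1.2-fold higher number from compound 2 to compound 3 (0.07 log units; within the scatter), so this exchange now has a measured size, and it cannot be told apart from the scatter, even though the group that leaves has 1 hydrogen-bond acceptor and the group that enters has 0 hydrogen-bond acceptors. With compound 3 added, three different groups have been seen at this position, and each compound lies within the scatter of the next, so the position has not yet produced a real difference in inhibition and all three compounds remain weak inhibitors. Nothing shown here bears on why the number holds so steady across these exchanges.

On these data alone, all three compounds carry a substituted phenyl ring at this position, so it remains open whether a different kind of group there, such as an amine, a carboxylic acid or a longer chain, would move the number beyond the scatter. As far as these compounds go, the rest of the shared core is the same in all three compounds, so what a change elsewhere would do also remains unknown.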